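The compounds below may be only part of what the source reports. "The series", "measured", "known", "first", "only" and "open" are said of these compounds alone.

Measured in a functional assay on MT4 cells (Homo sapiens) for cytotoxicity; a lower number here means a stronger inhibitor, a higher number a weaker inhibitor:
- Compound 1 `N#Cc1c(N)cccc1Sc1ccccc1`: 168000 nM
- Compound 2 `N#Cc1c(N)cccc1Sc1cccc(Br)c1`: 53000 nM

Of the two, compound 2 has the lower number, at 53000 nM. The next compound, compound 3 `N#Cc1c(N)cccc1Sc1cccc(N)c1`, carries amino in place of bromo on an aromatic carbon. Among the measured compounds shown here, only one measured step bears on this change, the arrival of the bromo, a 3.2-fold lower number from compound 1 to compound 2 (0.50 log units; beyond the scatter), which is modest in size. For the measured compounds named here, compound 3 loses that bromo, so a modest move back up is expected in this assay, although no measured compound shows what amino does here. The expected change is a 2.1-fold higher number from compound 2 to compound 3 (0.32 log units; beyond the scatter). Compound 3 is estimated at 110000 nM, with an expected range from 40000 nM to 300000 nM.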

Compound 3, half-maximal inhibitory concentration: 168000 nM
Estimate against measurement, compound 3: 1.5-fold (0.18 log units) below, within the range that was stated.
By their numbers in this assay, from the lowest: compound 2; then compounds 1 and 3 (each within the scatter of the next).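

In this assay, amino in place of bromo gives a 3.2-fold higher number from compound 2 to compound 3 (0.50 log units; beyond the scatter), while amino in place of hydrogen gives no change at the digits printed from compound 1 to compound 3 (within the scatter). At this position, then, the lower number seen with bromo does not carry over to amino: among the three groups shown, only bromo separates from the others. Nothing measured here explains this difference. On these data alone, what remains open is whether bromo stands alone at this position, or whether a group such as chloro, methyl or a carboxylic acid would also lower the number.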